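The compounds below may be only part of what the source reports. "The series", "measured", "known", "first", "only" and "open" are said of these compounds alone.

Compound 1 `Cc1cccc(C)c1Oc1cc(Nc2ccc(C#N)cc2)[nH]c(=O)c1Br` (63000 nM)
Compound 2 `Cc1cc(C#N)cc(C)c1Oc1cc(Nc2ccc(C#N)cc2)[nH]c(=O)c1Cl` (> 319000 nM)
Compound 3 `Cc1cc(C)c(Oc2cc(Nc3ccc([N+](=O)[O-])cc3)[nH]c(=O)c2)c(C)c1` (26000 nM)

All of these results come from an ADME assay on MT4 cells (Homo sapiens) for cytotoxicity, read by MTT assay, with a stated time of 5 days; a lower number here means that less compound is tolerated, a higher number that more compound is tolerated. Compound 3 (26000 nM) has the lower of the two actual numbers, and compound 1 (63000 nM) stands higher by more than the scatter. For compound 2 the result is only a limit (> 319000 nM).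

Compound 4 `Cc1cc(C)c(Oc2cc(Nc3ccc(C#N)cc3)[nH]c(=O)c2)c(C)c1` has not yet been measured. It differs from compound 3 in one place, with cyano in place of nitro on an aromatic carbon, para to a large group (cyano in place of nitro on an aromatic carbon). Among the compounds with values here, no measured pair isolates this change, so the expectation rests on indirect ground. Compound 1 also carries the 4-cyanophenyl group and gives a higher number (63000 nM), although its structure differs elsewhere as well. A moderate rise in this assay is therefore expected, with an estimated size (a 2.3-fold higher number from compound 3 to compound 4 (0.36 log units; beyond the scatter)) that would mean more compound is tolerated. The estimated value for compound 4 is 60000 nM, with an expected range from 18000 nM to 250000 nM.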

Compound 4, half-maximal cytotoxic concentration: 32000 nM
Estimate against measurement, compound 4: 1.9-fold (0.27 log units) above; the range from low to high includes it.
By their numbers in this assay, from the lowest: compounds 3, 4 and 1 (each within the scatter of the next, the first and the last beyond it). At a limit, above all of these: compound 2.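

In this assay the change of nitro to cyano, on an aromatic carbon para to a large group, gives a 1.2-fold higher number from compound 3 to compound 4 (0.09 log units; within the scatter) and is the first pair among these compounds to isolate a single change. On this shared core, therefore, 4-nitrophenyl and 4-cyanophenyl are not separated by this read-out, and the exchange alone produces no measurable difference in how much compound the cells tolerate. Nothing among the data available speaks to why the two groups read alike.

On these data alone, it remains open whether an amine or a carboxylic acid at this same place would read differently from nitro and cyano. As far as these compounds go, it is also open whether nitro and cyano would still read alike on the cores of compound 1 and compound 2.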